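A few compounds are considered here, and "the series" means these few. Any claim that something is new, unique, unknown or untested is made for them only; others in the source may bear on it.

Among the measured compounds shown here, compound 2 `CC(C)(C)c1cc(NC(=O)[C@@H]2CCCCN2CC2CC2)no1` stands at 0.15 h in an ADME assay (liver) for metabolic stability, with Liver microsome (Homo sapiens) as the target, read by LC-MS, using microsomes and NADPH, tested at 1 uM (on this read-out higher numbers stand for a longer-lived compound and lower numbers for a shorter-lived compound), the lowest of the two numbers so far; its nearest neighbour, compound 1 `CC(C)(C)c1cc(NC(=O)[C@@H]2CCCCN2C2CC2)no1`, gives 0.183 h. For the measured compounds named here, the one measured step, a 1.2-fold lower number from compound 1 to compound 2 (0.09 log units; within the scatter), is within the scatter. Compound 3 `CC(C)CN1CCCC[C@H]1C(=O)Nc1cc(C(C)(C)C)on1` differs from compound 2 by isopropyl in place of cyclopropyl on a saturated chain carbon bound to an amine nitrogen in a ring. Going by the values given here, no measured step matches this change; the step from compound 1 to compound 2 is the only guide, and it shows no movement beyond the scatter. For compound 3 a step of no change at the digits printed from compound 2 to compound 3 (within the scatter) is therefore expected. Compound 3 is estimated at 0.15 h, with a range from 0.07 h to 0.33 h.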

Compound 3, half-life: 0.1 h
Compound 3: the middle estimate sits 1.5-fold (0.18 log units) above what was measured; measured number inside the range.
By their numbers in this assay, from the lowest: compounds 3, 2 and 1 (each within the scatter of the next).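

Replacing the three-membered carbon ring with open-chain isopropyl on a saturated chain carbon bound to an amine nitrogen in a ring gives a step that stays inside the scatter in this assay (a 1.5-fold lower number from compound 2 to compound 3 (0.18 log units; within the scatter)). The widest pair so far, isobutyl against cyclopropyl on the ring nitrogen, also stays inside it (a 1.8-fold lower number from compound 1 to compound 3 (0.26 log units; within the scatter)). No information on the cause is available.

Going by these compounds, whether an ether chain, a carboxylic acid or a longer alkyl chain on this nitrogen would move the half-life beyond the scatter remains open.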